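Removing the Basic Side Chain from Compound 1

A few compounds are considered here, and "the series" means these few. Any claim that something is new, unique, unknown or untested is made for them only; others in the source may bear on it.

Measured compounds:
compound 1 `CN(C)CCCCCn1c2c(c3ccccc31)C(=O)c1c[n+]([O-])c3ccccc3c1C2=O` with 370 nM
compound 2 `O=C1c2c[n+]([O-])c3ccccc3c2C(=O)c2c1c1ccccc1n2Cc1cn([C@@H]2O[C@H](CO)[C@@H](O)[C@H](O)[C@H]2O)nn1` with 880 nM

In a functional assay on SH-SY5Y cells (Homo sapiens) for cytotoxicity, read by MTT assay, with a stated time of 72 h (a lower number here means a stronger inhibitor, a higher number a weaker inhibitor), compound 1 gives the lower of the two numbers, and compound 2 sits beyond the scatter above it. Compound 3 `O=C1c2c[n+]([O-])c3ccccc3c2C(=O)c2[nH]c3ccccc3c21` has not been measured. It differs from compound 1 in one place: hydrogen in place of 5-(dimethylamino)pentyl on an aromatic nitrogen. Among the compounds with values here, no single-point step between measured compounds is available to calibrate this change, so the expectation rests on compound 1 alone. For compound 3 a moderate weakening is expected, a step of a 4.1-fold higher number from compound 1 to compound 3 (0.61 log units; beyond the scatter) in this assay, giving an estimated 1500 nM within a range from 400 nM to 6000 nM.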

Compound 3, half-maximal inhibitory concentration: 1380 nM
Beside the measured number, compound 3's estimate is 1.1-fold (0.04 log units) above it; the measured number falls inside the stated range.
By their numbers in this assay, from the lowest: compound 1; then compounds 2 and 3 (each within the scatter of the next).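

Replacing 5-(dimethylamino)pentyl with hydrogen on the aromatic nitrogen gives a 3.7-fold higher number from compound 1 to compound 3 (0.57 log units; beyond the scatter) in this assay and this modest step shows that the group at this position affects the number. Even so, the core of compound 3, with no chain on this nitrogen, still gives 1380 nM without that group. Nothing at hand accounts for the step. On these data alone, whether the dimethylamino end or the pentyl chain carries the step remains open. So does the effect of a shorter pentyl-free alkyl chain, a primary amine or a carboxylic acid here.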